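The source may hold more compounds than are shown below. What is called first, only, known or untested is meant among the compounds shown, and "the series" means these compounds.

Compound 3 `CC1(C)CCC(C)(C)c2cc(/C=C\c3ccc(N)cc3)ccc21` gives 38000 nM in a functional assay on HL-60 cells (Homo sapiens), with a stated time of 48 h; a higher number here means that more compound is needed for the effect, a lower number that less compound is needed. Compound 2 `CC1(C)CCC(C)(C)c2cc(/C=C/c3ccc(N)cc3)ccc21` gives 38000 nM, and compound 1 `COc1ccc(/C=C\c2ccc3c(c2)C(C)(C)CCC3(C)C)cc1N` gives 50000 nM. Compound 3 therefore stands level with compound 2, the two together forming the lowest of the three numbers, while the gap to compound 1 lies within the scatter. Going by the values given here, the only measured step, no change at the digits printed from compound 2 to compound 3 (within the scatter), is no change, and it rests on (the fact that compounds 2 and 3 differ only in the configuration as drawn). Compound 4 `CC1(C)CCC(C)(C)c2cc(/C=C\c3cccc(N)c3)ccc21` differs from compound 3 by 3-aminophenyl in place of 4-aminophenyl on a double-bonded chain carbon bound to a double-bonded chain carbon. Among the compounds with values here, no measured step concerns a change of this kind, so the step from compound 2 to compound 3 offers little guidance. The three numbers lie close together, and compound 4 is expected to remain in that range, with a 1.1-fold higher number from compound 3 to compound 4 (0.02 log units; within the scatter) expected to stay within the scatter. Compound 4 is estimated at 40000 nM, between 15000 nM and 100000 nM.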

Compound 4, concentration for half-maximal activity: 10000 nM
Compound 4: the middle estimate sits 4.0-fold (0.60 log units) above what was measured; measured number outside the range, below it.
By their numbers in this assay, from the lowest: compound 4; then compounds 2, 3 and 1 (each within the scatter of the next).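

The position of the amine on this ring matters in a way the double-bond configuration did not: 3-aminophenyl in place of 4-aminophenyl brings a 3.8-fold lower number from compound 3 to compound 4 (0.58 log units; beyond the scatter) in this assay. Going by these compounds alone, with the amine kept, hydrogen in place of methoxy on an aromatic carbon brings a 5.0-fold lower number from compound 1 to compound 4 (0.70 log units; beyond the scatter), the first step beyond the scatter to involve that group. Nothing available accounts for either step. Going by these compounds, it remains open whether a hydroxyl group or a carboxylic acid in place of the amine would keep the lower number, and whether a double bond drawn E would do so with 3-aminophenyl.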